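A few compounds are considered here, and "the series" means these few. Any claim that something is new, unique, unknown or untested is made for them only; others in the source may bear on it.

Going by the values given here, compound 1, `CC(O)(C(=O)Nc1cccc(S(=O)(=O)c2ccccc2)c1)C(F)(F)F`, and compound 2, `CC(O)(C(=O)Nc1ccc(S(=O)(=O)c2ccccc2C#N)cc1)C(F)(F)F`, share the same trifluoromethyl-bearing hydroxy-amide core but differ from each other in more than one place, so no single step between them is stated and only their two values are given. In a functional assay (Cavia porcellus) with sulfonylurea receptors; K-ATP channels (Homo sapiens) as the target (a higher number here means a weaker inhibitor, a lower number a stronger inhibitor), compound 1 gives > 30000 nM, which is a limit of the assay and not a number, the limit noted as the limit of > 30000 nM in this assay, at which 1 of the 2 values shown sits. In this assay, among the compounds with values here, compound 2 gives 1100 nM, the only actual number among the values shown so far.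

Compound 3, `CC(O)(C(=O)Nc1ccc(S(=O)(=O)c2ccc(Br)cc2)cc1)C(F)(F)F`, is the next member to be run. Relative to compound 2 the change is 4-bromophenyl in place of 2-cyanophenyl on a sulfonyl sulfur. Within the data shown here, no measured step covers such an exchange on the sulfonyl sulfur, so the size of the step is open. A modest shift toward weaker inhibition is expected, a step of a 2.3-fold higher number from compound 2 to compound 3 (0.36 log units; beyond the scatter), close to the edge of the usual scatter rather than well beyond it. Compound 3 is therefore estimated at 2500 nM in this assay, with a range from 800 nM to 8000 nM.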

Compound 3, half-maximal inhibitory concentration: > 30000 nM
Compound 3 ended at the assay's limit; the forecaster's own chance of this, stated with the estimate: 10%; at least 12-fold (1.07 log units) between middle value and limit.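

Going by these compounds alone, the exchange of 2-cyanophenyl for 4-bromophenyl on a sulfonyl sulfur gives an at least 27-fold higher number from compound 2 to compound 3 (1.43 log units; beyond the scatter) in this assay, and this is the first step that can be read at a single place. It shows that the aryl group on the sulfonyl sulfur is not a neutral site in this assay, as this one exchange alone is enough to take the series from a measurable value to the limit. For compound 3 the read-out of > 30000 nM is a limit of the assay and not a number, and compound 2 remains the only member shown with an actual number: the limit of > 30000 nM in this assay, at which 2 of the 3 values shown sit.

Within the data shown here, the single step changes both the group and where it sits on the ring, so the loss of the nitrile and the gain of the bromine cannot be told apart here. As far as these compounds go, a 4-cyanophenyl or 2-bromophenyl group on the sulfonyl sulfur would separate these two changes, and how an amine or a carboxylic acid at that ring would read in this assay stays open.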